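A few compounds are considered here, and "the series" means these few. Any claim that something is new, unique, unknown or untested is made for them only; others in the source may bear on it.

Compound 1 `O=C(/C=C/c1ccccc1)c1ccc(N2C(=O)C=CC2=O)cc1` and compound 2 `COc1ccc(/C=C/C(=O)c2ccc(N3C(=O)C=CC3=O)cc2)cc1` share their core with compound 3 `O=C(/C=C/c1ccc([N+](=O)[O-])cc1)c1ccc(N2C(=O)C=CC2=O)cc1` and with compound 4 `O=C(O)c1ccc(/C=C/C(=O)c2ccc(N3C(=O)C=CC3=O)cc2)cc1`, which has not yet been measured. In a functional assay on CCRF-CEM cells (Homo sapiens) for cytotoxicity (a lower number here means a stronger inhibitor, a higher number a weaker inhibitor), compound 1 gives 9800 nM. Compound 2 gives 8400 nM in this assay, and the step of a 1.2-fold lower number from compound 1 to compound 2 (0.07 log units; within the scatter) stays within the scatter. For compound 3 this assay reports only a limit, > 500000 nM, so compound 3 stands at the weak end of the three measured compounds without a number of its own. The steps of an at least 51-fold higher number from compound 1 to compound 3 (1.70 log units; beyond the scatter) and an at least 59-fold higher number from compound 2 to compound 3 (1.77 log units; beyond the scatter) are both large, and compound 3 sitting at the limit of > 500000 nM in this assay, at which 1 of the 3 values shown sits, is what keeps its true position open.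

The change to compound 4 is carboxy in place of nitro on an aromatic carbon. Going by the values given here, no measured step shows a carboxy group on this ring, so the only guidance is that removing the nitro group returns toward compound 1 and compound 2. Compound 4 is therefore expected to regain some of the lost potency, and its estimate is 60000 nM, within 5000 nM to 500000 nM. The expected step of an at least 8.3-fold lower number from compound 3 to compound 4 (0.92 log units; beyond the scatter) is thus a move back toward the two numbered values, with wide uncertainty and a fair chance that again only a limit is reported.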

Compound 4, half-maximal inhibitory concentration: 133000 nM
Beside the measured number, compound 4's estimate is 2.2-fold (0.35 log units) below it; the range from low to high includes it.
By their numbers in this assay, from the lowest: compounds 2 and 1 (each within the scatter of the next); then compound 4. At a limit, above all of these: compound 3.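

In this assay, a 14-fold higher number from compound 1 to compound 4 (1.13 log units; beyond the scatter) and a 16-fold higher number from compound 2 to compound 4 (1.20 log units; beyond the scatter) are both large, so carboxy on this aromatic carbon gives up much of the potency seen with hydrogen or methoxy there. Going by these compounds alone, until now the only large loss at this place came with nitro and was known only through a limit, whereas compound 4 puts the first actual number on such a loss and shows that the position tolerates no simple swap of hydrogen for either of these two groups. Carboxy in place of nitro reads as an at least 3.7-fold lower number from compound 3 to compound 4 (0.57 log units; beyond the scatter), but this gives only a minimum for the step, and its full size stays unknown because compound 3 has only a limit and no number of its own: the limit of > 500000 nM in this assay, at which 1 of the 4 values shown sits.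

The compounds shown leave open whether an amine, a methyl ester or a nitrile on this same aromatic carbon would fall with carboxy and nitro or stay with hydrogen and methoxy. They also leave open whether carboxy would cost as much on another carbon of this ring, and what a hydroxy group or a longer chain would do here.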